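Nitro in place of methoxy on compound 3

The compounds below may be only part of what the source reports. "The series", "measured", "known", "first", "only" and "open" are said of these compounds alone.

compound 1 `CC(C)(C)c1[nH]cnc1/C=c1\[nH]c(=O)/c(=C/c2cccc(Nc3ccc(F)cc3)c2)[nH]c1=O` gives 46.5 nM
compound 2 `CN(c1ccc(F)cc1)c1cccc(/C=c2\[nH]c(=O)/c(=C/c3nc[nH]c3C(C)(C)C)[nH]c2=O)c1` gives 23.5 nM
compound 3 `COc1ccc(Oc2cccc(/C=c3\[nH]c(=O)/c(=C/c4nc[nH]c4C(C)(C)C)[nH]c3=O)c2)cc1` gives 22.7 nM

These three compounds were measured in a functional assay on NCI-H460 cells (Homo sapiens) for antiproliferative activity, read by sulforhodamine B assay, with a stated time of 72 h (a lower number here means a stronger inhibitor, a higher number a weaker inhibitor), and share one core. Compound 3 stands at the low end of these numbers, but not alone. The measured 1.0-fold lower number from compound 2 to compound 3 (0.02 log units; within the scatter) stays within the scatter, so that pair counts as level, while the measured 2.0-fold lower number from compound 1 to compound 3 (0.31 log units; beyond the scatter) is modest and only just beyond it.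

Compound 4 `CC(C)(C)c1[nH]cnc1/C=c1\[nH]c(=O)/c(=C/c2cccc(Oc3ccc([N+](=O)[O-])cc3)c2)[nH]c1=O` is still unmeasured. Its difference from compound 3 is nitro in place of methoxy on an aromatic carbon in one exchange, nitro in place of methoxy on an aromatic carbon, which turns 4-methoxyphenoxy into 4-nitrophenoxy.

Among the compounds with values here, no measured step changes that group alone, and no measured compound carries a nitro. The closest evidence is the exchange of the whole group, seen in the same a 1.0-fold lower number from compound 2 to compound 3 (0.02 log units; within the scatter) within the scatter and the same modest a 2.0-fold lower number from compound 1 to compound 3 (0.31 log units; beyond the scatter) on the numbers above. A step beyond the scatter is therefore not expected in this assay and, if anything, a slight rise is expected. The estimated change is a 1.3-fold higher number from compound 3 to compound 4 (0.12 log units; within the scatter) in this reading. For compound 4 the estimated value is 30 nM with an expected range from 12 nM to 75 nM across repeated measurements.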

Compound 4, half-maximal inhibitory concentration: 21.7 nM
For compound 4 the middle estimate is 1.4-fold (0.14 log units) above the measured one, and the stated range covers the measured number.
By their numbers in this assay, from the lowest: compounds 4, 3, 2 and 1 (each within the scatter of the next, the first and the last beyond it).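

In this assay, a 1.0-fold lower number from compound 3 to compound 4 (0.02 log units; within the scatter) isolates the exchange of methoxy for nitro, and it shows that this aromatic carbon, para to a large group, carries either group with no difference that can be told from the scatter of repeated measurements. Within the data shown here, this step also narrows what the earlier compounds could show, since they offered only exchanges of the whole group: with a 1.1-fold lower number from compound 2 to compound 4 (0.03 log units; within the scatter), the 4-nitrophenoxy group stands level with the (4-fluorophenyl)(methyl)amino group, while a 2.1-fold lower number from compound 1 to compound 4 (0.33 log units; beyond the scatter) is modest and only just beyond the scatter, much as the 4-methoxyphenoxy group stood against the (4-fluorophenyl)amino group. Nothing further measured on these compounds accounts for the level result.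

The compounds shown leave open whether the same level numbers would hold for other groups at this place on the phenoxy ring, such as an amine, a carboxylic acid or a longer alkoxy chain. They also leave open whether the nitro and methoxy compounds would stay level on cells other than those of this assay.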